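Compound 2 to compound 4: exchanging the terminal amine

The source may hold more compounds than are shown below. What is called first, only, known or untested is meant among the compounds shown, and "the series" means these compounds.

Measured in an ADME assay (liver) for metabolic stability, with Liver microsome (Homo sapiens) as the target, read by LC-MS, using microsomes, tested at 1 uM; a higher number here means that the compound lasts longer, a lower number that the compound disappears faster:
- Compound 1 `C/C(=N/c1ccnc2cc(Cl)ccc12)NCCCCN1CCCCC1`: > 1 h, a limit
- Compound 2 `CC(C)/C(=N/c1ccnc2cc(Cl)ccc12)NCCCCN1CCCCC1`: 0.483 h
- Compound 3 `C/C(=N/c1ccnc2cc(Cl)ccc12)NC1CCN(C(C)C)CC1`: > 1 h, a limit

Going by the values given here, compound 2 gives the only true number in this assay, at 0.483 h. The other two results are limits, not numbers: the limit of > 1 h in this assay, at which 2 of the 3 values shown sit.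

Among the compounds with values here, the single measured step is an at least 2.0-fold lower number from compound 1 to compound 2 (0.31 log units; beyond the scatter). It places isopropyl in the position of methyl on a carbon with a double bond to nitrogen, which is not the place of the change considered here, so its size does not carry over.

Compound 4 `CCN(CC)CCCCN/C(=N\c1ccnc2cc(Cl)ccc12)C(C)C` differs from compound 2 as follows: diethylamino in place of piperidin-1-yl on a saturated chain carbon, four bonds along the chain from an amine nitrogen. In words, this is diethylamino in place of piperidin-1-yl on a saturated chain carbon, four bonds along the chain from an amine nitrogen.

Within the data shown here, no measured step covers this exchange, and no direction can be read from the data. No step beyond the scatter is therefore expected in this assay, and the expectation stays with compound 2 at 0.483 h. The expected change is a 1.0-fold lower number from compound 2 to compound 4 (0.00 log units; within the scatter). For compound 4 the estimated half-life is 0.48 h, with an expected range from 0.22 h to 1 h.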

Compound 4, half-life: 0.917 h
For compound 4 the middle estimate is 1.9-fold (0.28 log units) below the measured one; the range from low to high includes it.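

Going by these compounds alone, this is the first reading at the terminal amine, a saturated chain carbon four bonds along the chain from an amine nitrogen. In this assay, the exchange of piperidin-1-yl for diethylamino gives a 1.9-fold higher number from compound 2 to compound 4 (0.28 log units; within the scatter), so this pair does not separate the ring-bearing amine from the open-chain one. The step at the carbon with a double bond to nitrogen, an at least 2.0-fold lower number from compound 1 to compound 2 (0.31 log units; beyond the scatter), lies beyond the scatter, so among the steps shown, only that one registers as a real difference, and the terminal amine exchange does not.

On these data alone, whether the same tolerance extends to other terminal groups, such as morpholin-4-yl or pyrrolidin-1-yl, or to a longer chain between the two nitrogens, remains open. The same amine exchange on the methyl side of the series would also be hard to read: the limit of > 1 h in this assay, at which 2 of the 4 values shown sit.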